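The source may report more compounds than this note shows. Statements on the series, on what has been measured and on what is new or still open speak of the compounds shown alone.

Compound 1 `N#Cc1ccc(Nc2nc(Oc3ccnc4ccccc34)nc(N3CCN(c4ccccc4Cl)CC3)n2)cc1C(F)(F)F` is the starting point of this account. In a functional assay on DU-145 cells (Homo sapiens) for cytotoxicity, read by sulforhodamine B assay, with a stated time of 48 h (on this read-out lower numbers stand for higher toxicity in this test and higher numbers for lower toxicity in this test), compound 1 gives > 100000 nM, which is a limit of the test and not a number. Compound 2 `N#Cc1ccc(Nc2nc(Oc3ccnc4ccccc34)nc(N3CCN(c4ccc(F)cc4)CC3)n2)cc1C(F)(F)F` is likewise known only through a limit, giving > 100000 nM in this assay. Compound 3 `CN1CCN(c2nc(Nc3ccc(C#N)c(C(F)(F)F)c3)nc(Oc3ccnc4ccccc34)n2)CC1` also gives > 100000 nM in this assay, again a limit. The steps a step that the two limits leave unreadable from compound 1 to compound 2, a step that the two limits leave unreadable from compound 1 to compound 3 and a step that the two limits leave unreadable from compound 2 to compound 3 can therefore not be read in size or in direction, since (the limit of > 100000 nM in this assay, at which 3 of the 3 values shown sit). Compound 4 `COc1ccc(N2CCN(c3nc(Nc4ccc(C#N)c(C(F)(F)F)c4)nc(Oc4ccnc5ccccc45)n3)CC2)cc1` differs from compound 1 in one place: 4-methoxyphenyl in place of 2-chlorophenyl on an amine nitrogen in a ring. For the measured compounds named here, none of the measured steps has a readable size, so the data give no direction for this change; what they do show is that three different groups on the same ring nitrogen all left the value at the limit. Compound 4 is therefore expected to give about 100000 nM, within 30000 nM to 300000 nM, most likely again as a limit. The step expected from compound 1 is a number no higher from compound 1 to compound 4 (the limit leaves the size open).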

Compound 4, concentration lethal to 50% of the cells: > 100000 nM
Compound 4: a limit, no number; the forecaster's own chance of this, stated with the estimate: 85%; the middle value sits exactly at the limit.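

Compound 4 also sits at a limit and gives no number, so its steps from compound 1, compound 2 and compound 3 cannot be read: the limit of > 100000 nM in this assay, at which 4 of the 4 values shown sit.

The compounds shown leave open whether any group on this ring nitrogen, or any change elsewhere on the shared core, would give a readable value in this assay.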